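Aryl amide variation on the shared core: compound 4

The source may hold more compounds than are shown below. What is called first, only, known or untested is meant among the compounds shown, and "the series" means these compounds.

Measured so far in a functional assay on Ramos cells (Homo sapiens) for antiproliferative activity, read by CCK-8 assay, with a stated time of 72 h, tested at 40 uM; on this read-out lower numbers stand for less inhibition and higher numbers for more inhibition at the one concentration tested (going by the name of the read-out):
compound 1 `CCOC(=O)c1sc(-c2cccc(NC(=O)c3ccc(Cl)cc3)c2)nc1Nc1ccc(N2CCN(C)CC2)cc1` gives 46.9%
compound 2 `CN1CCN(c2ccc(Nc3nc(-c4cccc(NC(=O)c5cccc(F)c5)c4)sc3C(=O)O)cc2)CC1` gives 82.7%
compound 3 `CN1CCN(c2ccc(Nc3nc(-c4cccc(NC(=O)c5ccccc5F)c4)sc3C(=O)O)cc2)CC1` gives 93.4%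

Compound 3 stands highest of the three numbers in this assay, with compound 2 nearest and compound 1 furthest, both steps beyond the scatter. Compound 4 `CN1CCN(c2ccc(Nc3nc(-c4cccc(NC(=O)c5ccc(Cl)cc5)c4)sc3C(=O)O)cc2)CC1` differs from compound 3 by 4-chlorophenyl in place of 2-fluorophenyl on a carbonyl carbon. For the measured compounds named here, the only measured step at this place, a number 10.7 percentage points higher from compound 2 to compound 3 (beyond the scatter), is modest. Going by the values given here, compound 1 also carries 4-chlorophenyl there but differs from compound 4 at a second place, so no step is available; its value shows only that the group is compatible with inhibition. A step of modest size, more likely downward than upward, is expected: a number 11.4 percentage points lower from compound 3 to compound 4 (beyond the scatter). Compound 4 is therefore estimated at 82%, within 62% to 95%.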

Compound 4, a percentage reported as inhibition, at one concentration (the size of the read-out at that concentration, not a potency): 71.6%
Compound 4: the middle estimate sits 10.4 percentage points above what was measured; the measured number falls inside the stated range.
By their numbers in this assay, from the lowest: compound 1; then compound 4; then compound 2; then compound 3.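

In this assay, the amide aryl group matters more than the first fluorine pair suggested: 4-chlorophenyl gives a number 21.8 percentage points lower from compound 3 to compound 4 (beyond the scatter) and also a number 11.1 percentage points lower from compound 2 to compound 4 (beyond the scatter) in the second comparison. With 4-chlorophenyl held fixed, hydrogen in place of ethyl on an oxygen next to a carbonyl group gives a number 24.7 percentage points higher from compound 1 to compound 4 (beyond the scatter) as a clean single-place step. No measurement here accounts for either change.

Still open, going by these compounds, is whether the drop follows the chlorine or the 4-position, and 4-fluorophenyl on the carboxylic acid core would separate these. A 2-chlorophenyl group would test the same question from the other side.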